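The compounds below may be only part of what the source reports. "The series", "measured", "known", "first", "only" and "open" are said of these compounds alone.

For the measured compounds named here, compound 3 `CN(C)CCn1cnnc1-c1cc(Oc2ccc(NC(=O)N/N=C/c3ccc(O)cc3)cc2F)ccn1` gives 3560 nM in a functional assay on A549 cells (Homo sapiens) for cytotoxicity, read by MTT assay, with a stated time of 72 h (on this read-out lower numbers stand for stronger inhibition and higher numbers for weaker inhibition), the highest of the three numbers so far; compound 1 `COc1ccc(OC)c(/C=N/NC(=O)Nc2ccc(Oc3ccnc(-c4nncn4CCN(C)C)c3)c(F)c2)c1` gives 1950 nM, a gap of a 1.8-fold higher number from compound 1 to compound 3 (0.26 log units; within the scatter), while compound 2 `CN(C)CCn1cnnc1-c1cc(Oc2ccc(NC(=O)N/N=C/c3ccc(Cl)cc3)cc2F)ccn1` gives 780 nM, a gap of a 4.6-fold higher number from compound 2 to compound 3 (0.66 log units; beyond the scatter). Compound 4 `CN(C)CCn1cnnc1-c1cc(Oc2ccc(NC(=O)N/N=C/c3cc(Br)c(O)c(Br)c3)cc2F)ccn1` awaits measurement. The change is 3,5-dibromo-4-hydroxyphenyl in place of 4-hydroxyphenyl on a carbon with a double bond to nitrogen, so the hydroxy stays and bromines are added. The step that bears on it is a 4.6-fold higher number from compound 2 to compound 3 (0.66 log units; beyond the scatter), where a halogen on that ring in place of hydroxy went with a lower number, and a 2.5-fold lower number from compound 1 to compound 2 (0.40 log units; beyond the scatter) points the same way for chloro. A modest lower number is therefore expected for compound 4, a 2.7-fold lower number from compound 3 to compound 4 (0.44 log units; beyond the scatter). Compound 4 is estimated at 1300 nM, with a range from 450 nM to 3800 nM.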

Compound 4, half-maximal inhibitory concentration: > 100000 nM
Compound 4 gave a limit, no number; the forecaster's own chance of this, stated with the estimate: 3%; middle value at least 76-fold (1.88 log units) from the limit.
By their numbers in this assay, from the lowest: compound 2; then compounds 1 and 3 (each within the scatter of the next). At a limit, above all of these: compound 4.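

On the carbon with a double bond to nitrogen, 3,5-dibromo-4-hydroxyphenyl in place of 4-hydroxyphenyl gives an at least 28-fold higher number from compound 3 to compound 4 (1.44 log units; beyond the scatter), so a halogen on this ring does not always go with a lower number. The same group also gives an at least 120-fold higher number from compound 2 to compound 4 (2.10 log units; beyond the scatter) and an at least 51-fold higher number from compound 1 to compound 4 (1.70 log units; beyond the scatter), so the three earlier rings sit far from it. The result for compound 4 is a limit and not a number: the limit of > 100000 nM in this assay, at which 1 of the 4 values shown sits.

The compounds shown leave open whether a single bromine, or two bromines without the hydroxy, would give the same result. They also leave open how an amine or a carboxylic acid on this ring would read.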